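The source may report more compounds than this note shows. Statements on the series, on what has been measured and on what is new or still open speak of the compounds shown alone.

Within the data shown here, compound 2 `Cc1nnc(SCC(=O)[C@H](CC(=O)O)NC(=O)[C@@H](NC(=O)COc2cccc3ccccc23)C(C)C)s1` gives 190000 nM in a functional assay on Jurkat cells (Homo sapiens) for inhibition (a higher number here means a weaker inhibitor, a lower number a stronger inhibitor), the highest of the two numbers so far; compound 1 `COC(=O)c1cc(OCC(=O)[C@H](CC(=O)O)NC(=O)[C@@H](NC(=O)COc2cccc3ccccc23)C(C)C)no1` gives 71000 nM in this assay. Among the measured compounds shown here, the one measured step, a 2.7-fold higher number from compound 1 to compound 2 (0.43 log units; beyond the scatter), sits at the same chain carbon as the next change and was modest. Compound 3 `CC(C)[C@H](NC(=O)COc1cccc2ccccc12)C(=O)N[C@@H](CC(=O)O)C(=O)CSc1nc2ccccc2o1` carries 1,3-benzoxazol-2-yl in place of 5-methyl-1,3,4-thiadiazol-2-yl on a sulfur. For the measured compounds named here, no step exchanges these two aryl groups directly; only the modest size of the step from compound 1 to compound 2 guides the expectation, so a modest step in this assay, direction uncertain, is expected: a 1.6-fold lower number from compound 2 to compound 3 (0.20 log units; within the scatter). Compound 3 is estimated at 120000 nM, within 40000 nM to 400000 nM.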

Compound 3, half-maximal inhibitory concentration: > 200000 nM
Compound 3 gave a limit, no number (the forecaster's own chance of this, stated with the estimate: 25%); at least 1.6-fold (0.22 log units) between middle value and limit.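

In this assay compound 3 gave a limit, not a number: the limit of > 200000 nM in this assay, at which 1 of the 3 values shown sits. Placing 1,3-benzoxazol-2-yl on the sulfur in place of 5-methyl-1,3,4-thiadiazol-2-yl gives an at least 1.0-fold higher number from compound 2 to compound 3 (0.02 log units; that floor lies within the scatter) and so does not separate the two aryl groups. The wider exchange gives an at least 2.8-fold higher number from compound 1 to compound 3 (0.44 log units; beyond the scatter) and places both sulfanyl groups shown on the weaker side of compound 1.

From the compounds shown here alone, how far compound 3 lies past compound 2 stays open. Also open, going by these compounds, is whether a simple phenoxy group or an amine on this saturated chain carbon would give a lower number than compound 1.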